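Bromo to Hydroxy on the Shared Core: Compound 4

This account rests on a few compounds, and the source may have more. Where it says the series, first, only, none or still open, it means among the compounds named here.

Measured so far, all in a functional assay on CCRF-CEM cells (Homo sapiens) for cytotoxicity, read by sulforhodamine B assay, with a stated time of 72 h; on this read-out lower numbers stand for stronger inhibition and higher numbers for weaker inhibition:
compound 1, `OCC#CCSc1cnc2ccccc2c1[Se]CC#CCBr`: 0.2 ug/mL
compound 2, `OCC#CCSc1cnc2ccccc2c1[Se]CC#CCO`: 1.4 ug/mL
compound 3, `C#CCSc1cnc2ccccc2c1[Se]CC#CCBr`: 0.3 ug/mL

Compound 3 stands second highest of the three numbers. Its nearest neighbour is compound 1, within the scatter, and its furthest is compound 2, beyond the scatter. Compound 4, `C#CCSc1cnc2ccccc2c1[Se]CC#CCO`, is not yet measured; it differs from compound 3 by hydroxy in place of bromo on a saturated chain carbon bound to a triple-bonded carbon.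

Among the measured compounds shown here, one measured step bears directly on this change: a 7.0-fold higher number from compound 1 to compound 2 (0.85 log units; beyond the scatter), the same replacement on the partner with a hydroxymethyl group. A step of about that size, in the same upward direction, is therefore expected in this assay for compound 4. Compound 4 is estimated at 2.1 ug/mL, with a range of 0.9 ug/mL to 5 ug/mL, meaning an expected step of a 7.0-fold higher number from compound 3 to compound 4 (0.85 log units; beyond the scatter).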

Compound 4, concentration for 50% inhibition: 3.2 ug/mL
The estimate for compound 4 lay 1.5-fold (0.18 log units) below the measured number, within the range that was stated.
By their numbers in this assay, from the lowest: compounds 1 and 3 (each within the scatter of the next); then compound 2; then compound 4.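

In this assay, hydroxy in place of bromo on a saturated chain carbon bound to a triple-bonded carbon also gives an 11-fold higher number from compound 3 to compound 4 (1.03 log units; beyond the scatter) when the partner chain lacks the hydroxymethyl group, so the rise in the number appears on both cores: the same change on two cores in this assay, a 7.0-fold higher number (0.85 log units; beyond the scatter) from compound 1 to compound 2 and an 11-fold higher number (1.03 log units; beyond the scatter) from compound 3 to compound 4, 1.5-fold (0.18 log units) apart, within the scatter of two such steps. On the hydroxy side, hydrogen in place of hydroxymethyl on a triple-bonded carbon gives a 2.3-fold higher number from compound 2 to compound 4 (0.36 log units; beyond the scatter), a step that agrees with its counterpart on the bromo side: the same change on two cores in this assay, a 1.5-fold higher number (0.18 log units; within the scatter) from compound 1 to compound 3 and a 2.3-fold higher number (0.36 log units; beyond the scatter) from compound 2 to compound 4, 1.5-fold (0.18 log units) apart, within the scatter of two such steps. The two changes thus read consistently across all four compounds.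

The compounds shown leave open how an amine or a chloro group on that saturated chain carbon would stand against bromo and hydroxy.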